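Weighing an amide against a urea on a shared core

A few compounds are considered here, and "the series" means these few. Any claim that something is new, unique, unknown or untested is made for them only; others in the source may bear on it.

Compound 1 `COc1cc(-c2nn(-c3cccc(NC(=O)c4cccc(C(F)(F)F)c4)c3)cc2-c2ccncc2)ccc1Cl`: 20100 nM
Compound 2 `COc1cc(-c2nn(-c3cccc(NC(=O)Nc4ccc(Cl)c(Cl)c4)c3)cc2-c2ccncc2)ccc1Cl`: 6460 nM
Compound 3 `O=C(Nc1cccc(-n2cc(-c3ccncc3)c(-c3ccc(Cl)c(O)c3)n2)c1)Nc1ccc(Cl)c(Cl)c1`: a limit, > 32500 nM

In a functional assay on HT-29 cells (Homo sapiens) for inhibition, read by sulforhodamine B assay, with a stated time of 48 h (on this read-out lower numbers stand for stronger inhibition of growth and higher numbers for weaker inhibition of growth), compound 2 gives 6460 nM, the lowest of the two plain numbers; compound 1 sits a 3.1-fold lower number from compound 1 to compound 2 (0.49 log units; beyond the scatter) away. Compound 3 reaches only a limit, > 32500 nM. The unmeasured compound 4 `COc1cc(-c2nn(-c3cccc(NC(=O)c4ccc(Cl)c(C(F)(F)F)c4)c3)cc2-c2ccncc2)ccc1Cl` differs from compound 2 by 4-chloro-3-(trifluoromethyl)phenyl in place of (3,4-dichlorophenyl)amino on a carbonyl carbon. The step that bears on it is a 3.1-fold lower number from compound 1 to compound 2 (0.49 log units; beyond the scatter), where a urea replaced an amide and the number fell; compound 4 returns to an amide, so the reverse is expected: a modest rise in this assay, softened only by the extra chloro the new group carries. Compound 4 is therefore expected at 13000 nM, in a range from 4500 nM to 32000 nM, which means a step of a 2.0-fold higher number from compound 2 to compound 4 (0.30 log units; within the scatter).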

Compound 4, concentration for total growth inhibition: > 32500 nM
Compound 4: only a limit was reported; the forecaster's own chance of this, stated with the estimate: 15%; at least 2.5-fold (0.39 log units) between middle value and limit.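

In this assay, an at least 5.0-fold higher number from compound 2 to compound 4 (0.70 log units; beyond the scatter): this place on the carbonyl carbon tolerates the swap of (3,4-dichlorophenyl)amino for 4-chloro-3-(trifluoromethyl)phenyl poorly, and the extra chloro does not restore growth inhibition. The other step, an at least 1.6-fold higher number from compound 1 to compound 4 (0.20 log units; that floor lies within the scatter), shows no gain from that chloro, yet does not establish a real loss. The value of compound 4 is a limit: the limit of > 32500 nM in this assay, at which 2 of the 4 values shown sit.

The step from compound 2 changes the link and the ring substituents together, so their shares stay unseparated. A urea carrying (4-chloro-3-(trifluoromethyl)phenyl)amino on the carbonyl carbon would be needed to tell them apart.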